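Amide substituent changes in a bis-indole dimer cytotoxicity series

The compounds below may be only part of what the source reports. "The series", "measured", "known", "first", "only" and "open" are said of these compounds alone.

Compound 1 `CN1[C@@H]2c3[nH]c4ccccc4c3C[C@H]1[C@H](C#N)N1[C@@H](CNC(=O)c3cccc(C(F)(F)F)c3)c3[nH]c4ccccc4c3C[C@@H]21` is the starting point. Within the data shown here, in a functional assay on HepG2 cells (Homo sapiens) for cytotoxicity, read by MTT assay, with a stated time of 72 h (a lower number here means a stronger inhibitor, a higher number a weaker inhibitor), compound 1 gives 340 nM, the lowest of the two numbers so far; its nearest neighbour is compound 2 `CCc1ccc(C(=O)NC[C@H]2c3[nH]c4ccccc4c3C[C@H]3[C@H]4c5[nH]c6ccccc6c5C[C@@H]([C@H](C#N)N23)N4C)cc1`, which in this assay gives 570 nM. Among the measured compounds shown here, the one measured step, 4-ethylphenyl in place of 3-(trifluoromethyl)phenyl on a carbonyl carbon, gives a 1.7-fold higher number from compound 1 to compound 2 (0.22 log units; within the scatter), so the two compounds cannot be ranked against each other.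

Compound 3 `CN1[C@@H]2c3[nH]c4ccccc4c3C[C@H]1[C@H](C#N)N1[C@@H](CNC(=O)/C=C/c3cccc(C(F)(F)F)c3)c3[nH]c4ccccc4c3C[C@@H]21` differs from compound 1 as follows: 2-(3-(trifluoromethyl)phenyl)ethenyl in place of 3-(trifluoromethyl)phenyl on a carbonyl carbon. For the measured compounds named here, no measured step inserts a double bond between the carbonyl carbon and the aromatic ring; the only step in hand exchanges one aromatic group for another and stays within the scatter. The shared core and the amide are untouched in both changes. On this basis no step beyond the scatter is expected in this assay for compound 3 in either direction, and the estimated step is a 1.2-fold higher number from compound 1 to compound 3 (0.07 log units; within the scatter). Going by the values given here, the estimate for compound 3 in this assay is 400 nM, with a range from 150 nM to 1100 nM, the width reflecting that the change has no measured precedent.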

Compound 3, half-maximal inhibitory concentration: 540 nM
The estimate for compound 3 lay 1.4-fold (0.13 log units) below the measured number; the measured number falls inside the stated range.
By their numbers in this assay, from the lowest: compounds 1, 3 and 2 (each within the scatter of the next).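

On the carbonyl carbon of the amide, the double bond that comes in with 2-(3-(trifluoromethyl)phenyl)ethenyl in place of 3-(trifluoromethyl)phenyl gives no readable shift in this assay, with a 1.6-fold higher number from compound 1 to compound 3 (0.20 log units; within the scatter). Among these compounds, this is the first sign that the aromatic ring can be held further out from the carbonyl carbon, through an added double bond, without a step beyond the scatter, whereas the earlier step only exchanged one aromatic group for another. The comparison with the 4-ethylphenyl amide gives a 1.1-fold lower number from compound 2 to compound 3 (0.02 log units; within the scatter), so the three amide groups remain unranked, and no measurement beyond these cytotoxicity numbers bears on the result.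

All three groups shown carry one six-membered aromatic ring of carbon only, so it remains open whether an amine or a carboxylic acid on this carbonyl carbon would move the number beyond the scatter. Going by these compounds, it is also open whether the saturated 2-(3-(trifluoromethyl)phenyl)ethyl group would behave like the ethenyl group, which would separate the double bond from the longer chain.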